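The compounds below may be only part of what the source reports. "The series", "measured", "known", "first", "only" and "open" are said of these compounds alone.

Working notes on the series. Compound 1 `NC(=O)Nc1sc(-c2ccccc2)cc1C(=O)NCC1CNCCO1` and compound 3 `NC(=O)Nc1sc(-c2ccccc2)cc1C(=O)NC1CCNCC1` carry the same shared core as the rest, but in a functional assay on HT-29 cells (Homo sapiens) (a lower number here means that less compound is needed, a higher number that more compound is needed for the effect), compound 1 gives "not determined" (no result reported) and compound 3 gives "not determined" (no result reported). Within the data shown here, compound 2 `CN(C)c1ccc(-c2cc(C(=O)N[C@H]3CCCNC3)c(NC(N)=O)s2)cc1` is the only member with a number: in this assay compound 2 gives 90 nM. Among the measured compounds shown here, with a single value there is no step between measured compounds to lean on, and nothing can be said about how the variation at the amide side affects the read-out.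

The next entry is compound 4 `NC(=O)Nc1sc(-c2ccc(C(N)=O)cc2)cc1C(=O)N[C@H]1CCCNC1`, which differs from compound 2 in one place: carbamoyl in place of dimethylamino on an aromatic carbon. The change sits on an aromatic carbon of a six-membered aromatic ring of carbon only, swapping a group with no hydrogen-bond donor for one with one donor and one acceptor.

For the measured compounds named here, no measured pair shows what such a swap does here, so the expectation rests on compound 2 alone. The step of a 2.2-fold higher number from compound 2 to compound 4 (0.35 log units; beyond the scatter) is expected to be small, toward somewhat more compound being needed, and may well stay within the scatter. Compound 4 is therefore estimated at 200 nM in this assay, with a range from 60 nM to 700 nM.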

Compound 4, half-maximal effective concentration: 3200 nM
The estimate for compound 4 lay 16-fold (1.20 log units) below the measured number; measured number above the stated range.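

In this assay, among these compounds, the change from 4-(dimethylamino)phenyl to 4-carbamoylphenyl gives a 36-fold higher number from compound 2 to compound 4 (1.55 log units; beyond the scatter), the first readable step, so this place on the aromatic ring is clearly not indifferent to the group it carries. The leaving and entering groups have the same number of heavy atoms, so the step is not tied to a change in that count. The swap does add a hydrogen-bond donor and a double bond outside aromatic rings, but this single pair cannot show which of these differences, if either, goes with the higher number.

Going by these compounds, whether a primary amine, a carboxylic acid or a nitrile on the same aromatic carbon would fall nearer to compound 2 or to compound 4 stays open. Also open, on these data alone, is whether the same swap gives a step of this size when the amide side carries a longer chain in place of the ring found in compound 2. Nothing at hand gives a measured reason for the size of this step.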